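Cytotoxicity notes: from compound 2 to compound 3

The source may report more compounds than this note shows. Statements on the series, on what has been measured and on what is new or still open speak of the compounds shown alone.

In an ADME assay on HEK-293T cells (Homo sapiens) for cytotoxicity, read by CCK-8 assay, with a stated time of 48 h (a higher number here means a weaker inhibitor, a lower number a stronger inhibitor), compound 1 (`COc1cccc(NC(=O)NCCNS(=O)(=O)c2ccc(-c3ccccc3OCc3ccccc3)s2)c1`) gives > 20000 nM as a limit of the assay. For the measured compounds named here, compound 2 (`COc1cccc(NC(=O)NCCNS(=O)(=O)c2ccc(-c3ccccc3Oc3ccc([N+](=O)[O-])c([N+](=O)[O-])c3)s2)c1`) stands at 17800 nM as the only actual number. Going by the values given here, the one measured step of an at least 1.1-fold lower number from compound 1 to compound 2 (0.05 log units; that floor lies within the scatter) lies at a different place in the molecule and offers no direct guide here. Compound 3 (`COc1ccc(NC(=O)NCCNS(=O)(=O)c2ccc(-c3ccccc3Oc3ccc([N+](=O)[O-])c([N+](=O)[O-])c3)s2)cc1`) differs by 4-methoxyphenyl in place of 3-methoxyphenyl on an amide-type nitrogen. Among the compounds with values here, no measured step touches that place, so no shift beyond the scatter is expected in this assay for this change. The estimated step of a 1.1-fold lower number from compound 2 to compound 3 (0.05 log units; within the scatter) is expected to stay within the scatter. The expected value for compound 3 is 16000 nM (estimated range 8000 nM to 20000 nM).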

Compound 3, half-maximal inhibitory concentration: 18500 nM
Compound 3: middle estimate off by 1.2-fold (0.06 log units), on the low side; measured number inside the range.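

In this assay, 4-methoxyphenyl in place of 3-methoxyphenyl on the amide-type nitrogen gives the first step read at this position: a 1.0-fold higher number from compound 2 to compound 3 (0.02 log units; within the scatter). Unlike the earlier step, this one rests on two actual numbers rather than a limit, and it shows that moving the methoxy group leaves the reading unchanged with the 3,4-dinitrophenyl group held constant. Room for higher readings is small: the limit of > 20000 nM in this assay, at which 1 of the 3 values shown sits.

From the compounds shown here alone, whether an amine or a carboxylic acid in place of the methoxy group would shift the number stays open. So does whether the same swap behaves alike with the benzyl group of compound 1.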